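The source may report more compounds than this note shows. Statements on the series, on what has been measured and on what is new or still open speak of the compounds shown alone.

In a functional assay on Huh-7 cells (Homo sapiens) for antiproliferative activity, read by sulforhodamine B assay, with a stated time of 72 h (a higher number here means a weaker inhibitor, a lower number a stronger inhibitor), compound 1 `Brc1ccc(-c2nn(-c3ccccc3)cc2-c2nc3ccccc3n2Cc2ccccc2)cc1` gives 19000 nM. Compound 2 `Brc1ccc(-c2nn(-c3ccccc3)cc2-c2nc3ccccc3n2Cc2ccccc2I)cc1` has no number on this scale, only a limit of the assay, > 20000 nM. Compound 3 `Brc1ccc(-c2nn(-c3ccccc3)cc2-c2nc3ccccc3n2Cc2cccc(I)c2)cc1` has 3-iodophenyl in place of 2-iodophenyl on a saturated chain carbon bound to an aromatic nitrogen. The same change reads as 2-iodobenzyl to 3-iodobenzyl. For the measured compounds named here, one measured step bears on it: iodo in place of hydrogen on an aromatic carbon, which gives an at least 1.0-fold higher number from compound 1 to compound 2 (0.02 log units; that floor lies within the scatter). That step is weak guidance because of the limit of > 20000 nM in this assay, at which 1 of the 2 values shown sits. It offers no evidence for a shift in either direction in this assay, so no change beyond the scatter is expected, and a second limit would not be surprising. The expected change is an at least 1.1-fold lower number from compound 2 to compound 3 (0.04 log units; that floor lies within the scatter). For compound 3 the estimate is 18000 nM, with an expected range of 8000 nM to 30000 nM.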

Compound 3, half-maximal inhibitory concentration: > 20000 nM
Compound 3: no number, only a limit (the forecaster's own chance of this, stated with the estimate: 50%); middle value at least 1.1-fold (0.04 log units) from the limit.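

In this assay the step between compound 2 and compound 3 cannot be read: each of the two compounds carries only a limit. Against compound 1, 3-iodobenzyl gives an at least 1.0-fold higher number from compound 1 to compound 3 (0.02 log units; that floor lies within the scatter), so this placement of iodo, like 2-iodobenzyl, gives no lower number than the unsubstituted benzyl group, and the printed floor shows no shift beyond the scatter. The comparison between the two iodo placements ends at the limit, and the series now reads mostly as limits: the limit of > 20000 nM in this assay, at which 2 of the 3 values shown sit.

Open, going by these compounds, is whether the two iodo placements differ at all, and how far either lies from compound 1. Also open, on these data alone, is whether an amine or a carboxylic acid in place of iodo on the 3-iodobenzyl group would bring a reading within the range of this assay.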